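The compounds below may be only part of what the source reports. "The series", "measured", "known", "first", "only" and "open" are said of these compounds alone.

Among the measured compounds shown here, compound 2 `CC(=O)Cn1cc(CNC(=O)c2cnc(Nc3ccc(C#N)cc3)cc2Oc2c(C)cc(C)cc2C)nn1` is the only compound of this pair with a number rather than a limit: in an ADME assay on MT4 cells (Homo sapiens) for cytotoxicity, read by MTT assay, with a stated time of 5 days (a higher number here means that more compound is tolerated, a lower number that less compound is tolerated), compound 2 gives 19400 nM. Compound 1 `Cc1cc(C)c(Oc2cc(Nc3ccc(C#N)cc3)ncc2C(=O)NCc2cn(Cc3ccccc3Cl)nn2)c(C)c1` is recorded only as a limit of the assay, >= 188000 nM in this assay, and that limit is the point described by the limit of >= 188000 nM in this assay, at which 1 of the 2 values shown sits. For the measured compounds named here, the one measured step, an at least 9.6-fold lower number from compound 1 to compound 2 (0.98 log units; beyond the scatter), therefore lies wholly at the saturated chain carbon bound to the aromatic nitrogen, where acetyl took the place of 2-chlorophenyl.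

Compound 3 `COC(=O)Cn1cc(CNC(=O)c2cnc(Nc3ccc(C#N)cc3)cc2Oc2c(C)cc(C)cc2C)nn1` changes the same region again, but within the acetyl group: methoxy in place of methyl on a carbonyl carbon. Going by the values given here, no measured step swaps methyl for methoxy on a carbonyl carbon, so the recorded step is only a rough guide; it concerned the loss of a ring, which compound 3 keeps unchanged relative to compound 2. The expectation is a step no larger than the scatter, a 1.2-fold higher number from compound 2 to compound 3 (0.09 log units; within the scatter), in this assay. Compound 3 is accordingly estimated at 24000 nM, within a range from 9000 nM to 65000 nM.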

Compound 3, half-maximal cytotoxic concentration: 13800 nM
For compound 3 the middle estimate is 1.7-fold (0.24 log units) above the measured one; the measured number falls inside the stated range.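

In this assay, methoxy in place of methyl on the carbonyl carbon gives a 1.4-fold lower number from compound 2 to compound 3 (0.15 log units; within the scatter), so acetyl and methoxycarbonyl cannot be told apart at this position. A second carbonyl-bearing group on the saturated chain carbon bound to an aromatic nitrogen now stands against 2-chlorophenyl, and it too gives a step beyond the scatter, an at least 13-fold lower number from compound 1 to compound 3 (1.13 log units; beyond the scatter), so the earlier step is no longer confined to acetyl. Compound 1 stands only as a limit of the assay: the limit of >= 188000 nM in this assay, at which 1 of the 3 values shown sits.

Still open, from the compounds shown here alone, is whether the lower number goes with the carbonyl itself or simply with the loss of the 2-chlorophenyl ring, and how large either step truly is. A carboxylic acid or a primary amide in place of methoxycarbonyl, or an unsubstituted phenyl in place of 2-chlorophenyl, would help separate these readings.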